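Removing One Chloro From a Purine Cytotoxic Agent

A few compounds are considered here, and "the series" means these few. Any claim that something is new, unique, unknown or untested is made for them only; others in the source may bear on it.

Compound 1 `ClCc1ccc(Cn2cnc3nc(Cl)nc(Cl)c32)cc1` gives 5880 nM in a functional assay on SF-295 cells (Homo sapiens) for cytotoxicity, read by sulforhodamine B assay, with a stated time of 48 h (a lower number here means that less compound is tolerated, a higher number that more compound is tolerated), the lower of the two numbers recorded so far; compound 2 `Nc1nc(Cl)c2ncn(Cc3cccc(CCl)c3)c2n1` gives 39800 nM in this assay. Compound 3 `ClCc1ccc(Cn2cnc3ncnc(Cl)c32)cc1` differs from compound 1 by hydrogen in place of chloro on an aromatic carbon. Within the data shown here, no measured pair shows this exact change, so the expectation rests on the structural change alone: a modest rise in the tolerated concentration is expected from compound 1 to compound 3, of roughly a 2.0-fold higher number from compound 1 to compound 3 (0.31 log units; beyond the scatter). Compound 3 is therefore estimated at 12000 nM, within a range of 4000 nM to 40000 nM.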

Compound 3, concentration lethal to 50% of the cells: 17000 nM
Compound 3: the middle estimate sits 1.4-fold (0.15 log units) below what was measured; the range from low to high includes it.
By their numbers in this assay, from the lowest: compound 1; then compound 3; then compound 2.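

Replacing the chloro between two ring nitrogen atoms with hydrogen gives a 2.9-fold higher number from compound 1 to compound 3 (0.46 log units; beyond the scatter) in this assay. Among these compounds, this is the first direct reading at this position, and it shows that this single chloro influences the result, with more compound tolerated once it is gone. No available measurement explains the shift. On these data alone, whether a methyl or a methoxy group at this same position would raise or lower the number remains open. So does whether removing the remaining chloro group would produce a similar change.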